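Nitrophenyl for methyl on the amine arm

The compounds below may be only part of what the source reports. "The series", "measured", "known", "first", "only" and "open" are said of these compounds alone.

Of the compounds shown here, three sharing one core have been tested in a functional assay on SK-MEL-2 cells (Homo sapiens) for inhibition, read by sulforhodamine B assay, with a stated time of 72 h; on this read-out higher numbers stand for weaker inhibition and lower numbers for stronger inhibition. Compound 1 `Cc1cc(=O)c2ccc(O)c(CN(Cc3ccccc3)Cc3ccccc3)c2o1` gives 17.8 ug/mL. Compound 2 `COc1ccc(CN(Cc2ccccc2)Cc2c(O)ccc3c(=O)cc(C)oc23)cc1` gives 78.6 ug/mL, and the change of methoxy in place of hydrogen on an aromatic carbon reads as a 4.4-fold higher number from compound 1 to compound 2 (0.65 log units; beyond the scatter). Compound 3 `CCN(Cc1ccc(OC)cc1)Cc1c(O)ccc2c(=O)cc(C)oc12` gives 60.3 ug/mL; the change of methyl in place of phenyl on a saturated chain carbon bound to an amine nitrogen reads as a 1.3-fold lower number from compound 2 to compound 3 (0.12 log units; within the scatter), so compound 3 stands second highest of the three numbers, close to compound 2 and well apart from compound 1.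

Compound 4 `COc1ccc(CN(Cc2ccc([N+](=O)[O-])cc2)Cc2c(O)ccc3c(=O)cc(C)oc23)cc1` has not yet been measured. It differs from compound 3 by 4-nitrophenyl in place of methyl on a saturated chain carbon bound to an amine nitrogen. For the measured compounds named here, the only measured step that bears directly on this place is the one from compound 2 to compound 3, where swapping phenyl and methyl on that same carbon stayed within the scatter. Going by the values given here, putting an aromatic ring back there should therefore move little; the nitro group on that ring has no counterpart among the measured compounds, so its effect is unknown. The expected step is a 1.2-fold higher number from compound 3 to compound 4 (0.06 log units; within the scatter), essentially none beyond the scatter. Compound 4 is estimated at 70 ug/mL, with a range from 30 ug/mL to 160 ug/mL.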

Compound 4, half-maximal inhibitory concentration: > 100 ug/mL
Compound 4 gave a limit, no number (the forecaster's own chance of this, stated with the estimate: 10%); at least 1.4-fold (0.15 log units) between middle value and limit.
By their numbers in this assay, from the lowest: compound 1; then compounds 3 and 2 (each within the scatter of the next). At a limit, above all of these: compound 4.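

With the 4-nitrophenyl group on this saturated chain carbon bound to an amine nitrogen, compound 4 gives > 100 ug/mL in this assay, which is a limit of the assay and not a number. Measured against the methyl group, the change gives an at least 1.6-fold higher number from compound 3 to compound 4 (0.21 log units; that floor lies within the scatter), and nitro in place of hydrogen on an aromatic carbon gives an at least 1.2-fold higher number from compound 2 to compound 4 (0.10 log units; that floor lies within the scatter). For the compounds shown here, both figures are floors, so the true steps could be larger, but neither floor alone passes the scatter; what the result does add is that nitro on this ring brought no sign of stronger inhibition, and no number lower than those of the earlier compounds.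

Still open, going by these compounds, is whether a real weakening, if there is one, belongs to nitro itself, which an amine or a carboxylic acid at the same place on that ring, or a longer chain in place of the methyl group of compound 3, could help to show. Also open, on these data alone, is how nitro would read on compound 1, which carries no methoxy group and has the lowest number so far.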